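Chloro for ethoxy on compound 3

This account rests on a few compounds, and the source may have more. Where it says the series, first, only, none or still open, it means among the compounds named here.

In a physicochemical assay for lipophilicity (on this read-out higher numbers stand for higher lipophilicity and lower numbers for lower lipophilicity), compound 3 (`CCOc1cc(S(=O)(=O)CC)ccc1-c1cc(-c2cnnc3c2ncn3CC)ccc1F`) gives 3.3 and stands highest of the three numbers, with compound 2 (`CCn1cnc2c(-c3ccc(F)c(-c4ccc(S(=O)(=O)CC)cc4)c3)cnnc21`) at 2.9 as its nearest neighbour and compound 1 (`N#Cc1ccc(Oc2cc(-c3cnnc4c3ncn4C3CC3)ccc2F)nc1`) at 2.3 as the furthest. Compound 4 (`CCn1cnc2c(-c3ccc(F)c(-c4ccc(S(=O)(=O)CC)cc4Cl)c3)cnnc21`) has chloro in place of ethoxy on an aromatic carbon. Among the compounds with values here, one measured step bears on this place, modest and beyond the scatter: a number 0.40 log units higher from compound 2 to compound 3 (beyond the scatter) for ethoxy in place of hydrogen. Chloro has no measured step of its own, so compound 4 is expected to give back only part of that step. The expected change in this assay is small and downward, with a number 0.10 log units lower from compound 3 to compound 4 (within the scatter) estimated and not beyond the scatter. Compound 4 is estimated at 3.2 with an expected range from 2.8 to 3.5 for now.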

Compound 4, distribution coefficient: 3.2
For compound 4 middle estimate and measured number coincide at the digits printed; low and high end bracket the measured number.
By their numbers in this assay, from the lowest: compound 1; then compounds 2, 4 and 3 (each within the scatter of the next, the first and the last beyond it).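

In this assay, chloro and ethoxy on this aromatic carbon cannot be told apart (a number 0.10 log units lower from compound 3 to compound 4 (within the scatter)). Chloro in place of hydrogen gives a step that does not clear the scatter (a number 0.30 log units higher from compound 2 to compound 4 (within the scatter)), whereas ethoxy in place of hydrogen does (a number 0.40 log units higher from compound 2 to compound 3 (beyond the scatter)). No measurement in hand accounts for these numbers.

Open, from the compounds shown here alone, is how an amine, a carboxylic acid or a longer alkoxy chain on this carbon would read in this assay. Also open, going by these compounds, is whether chloro would behave alike on the core of compound 1.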